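The source may hold more compounds than are shown below. What is called first, only, known or untested is meant among the compounds shown, and "the series" means these compounds.

Working notes on the series, all read in a functional assay on HT-29 cells (Homo sapiens) for antiproliferative activity, read by MTT assay, with a stated time of 24 h; a lower number here means a stronger inhibitor, a higher number a weaker inhibitor. Compound 1 (`COc1ccc(C(=O)/C=C/c2cccc(F)c2)c2c1C=CC(C)(C)O2`) gives > 10000 nM, which is a limit of the assay and not a number. Compound 2 (`COc1ccc(C(=O)/C=C/c2ccc(C(F)(F)F)cc2)c2c1C=CC(C)(C)O2`) gives > 10000 nM, which is again a limit. Compound 3 (`COc1ccc(/C=C/C(=O)c2ccc(OC)c3c2OC(C)(C)C=C3)cn1`) gives > 10000 nM, also a limit, so compound 3 has no number of its own. The measured set as a whole shares (the limit of > 10000 nM in this assay, at which 3 of the 3 values shown sit).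

Compound 4 (`COc1ccc(C(=O)/C=C/c2ccc(Cl)cc2)c2c1C=CC(C)(C)O2`) has 4-chlorophenyl in place of 6-methoxypyridin-3-yl on a double-bonded chain carbon bound to a double-bonded chain carbon. Among the compounds with values here, the one measured step at this place is a step that the two limits leave unreadable from compound 1 to compound 3, and it gives no size to carry over. Compound 1, compound 2 and compound 3 carry different groups at this place, yet all three end at a limit, and none offers a number to scale from.

The expectation rests on compound 3 and its limit of > 10000 nM. No step beyond the scatter, in either direction, is expected in this assay, and the estimated step that the limit leaves unreadable from compound 3 to compound 4 is only nominal. The estimate for compound 4 is 14000 nM, with an expected range from 6000 nM to 30000 nM, and a report as a limit alone is the likeliest outcome.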

Compound 4, half-maximal inhibitory concentration: > 10000 nM
Compound 4: no number, only a limit; the forecaster's own chance of this, stated with the estimate: 80%; the middle value does not contradict the limit.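

In this assay compound 4 gives > 10000 nM, which is a limit and not a number. No step from compound 1, compound 2 or compound 3 to compound 4 can be read, and the set shares one ceiling: the limit of > 10000 nM in this assay, at which 4 of the 4 values shown sit.

The compounds shown leave open which group at this place, if any, would give a measurable value.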